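Moving the fluorine around the aniline ring of compound 2

A few compounds are considered here, and "the series" means these few. Any claim that something is new, unique, unknown or untested is made for them only; others in the source may bear on it.

Compound 1, `COc1cc2ncnc(Nc3ccc(Br)cc3Cl)c2c(OC)c1OC`, gives -8.4% in a functional assay on PC-3 cells (Homo sapiens) for inhibition, read by MTT assay, with a stated time of 72 h, tested at 1 uM; a higher number here means more inhibition of growth at the concentration tested, a lower number less inhibition of growth.
Compound 2, `COc1cc2ncnc(Nc3ccc(F)cc3)c2c(OC)c1OC`, gives 3.1% in this assay.

Going by the values given here, compound 2 stands at the higher of the two numbers, and the single measured step, a number 11.5 percentage points higher from compound 1 to compound 2 (beyond the scatter), ends at it. Both numbers are small: neither compound holds back the growth of these cells to any marked degree at the concentration used.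

Compound 3, `COc1cc2ncnc(Nc3ccccc3F)c2c(OC)c1OC`, has not yet been measured. It differs from compound 2 by 2-fluorophenyl in place of 4-fluorophenyl on a nitrogen on an aromatic ring. Among the compounds with values here, only one measured step bears on this kind of change: a number 11.5 percentage points higher from compound 1 to compound 2 (beyond the scatter), which swapped a differently substituted ring onto the same nitrogen and shifted the number only modestly. Nothing measured speaks directly to moving a single fluorine to another spot on the ring.

Because compound 2 gives 3.1%, close to no growth inhibition, compound 3 is expected to stay near it, with a change of a number 3.1 percentage points lower from compound 2 to compound 3 (within the scatter) that would fall within the scatter. Compound 3 is therefore estimated at 0% in this assay, with a range from -12% to 12%.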

Compound 3, percent growth inhibition at one concentration: 0.9%
Compound 3: the middle estimate sits 0.9 percentage points below what was measured; the measured number falls inside the stated range.
By their numbers in this assay, from the lowest: compounds 1, 3 and 2 (each within the scatter of the next, the first and the last beyond it).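

In this assay, the step of a number 2.2 percentage points lower from compound 2 to compound 3 (within the scatter) shows that, for a single fluorine, 2-fluorophenyl in place of 4-fluorophenyl on this nitrogen gives no difference that can be told from the scatter. The earlier pair could not show this, as its two rings differed in more than the site of one halogen. The second new step, a number 9.3 percentage points higher from compound 1 to compound 3 (within the scatter), also stays inside the scatter, so compound 3 cannot be told apart from either compound 1 or compound 2, even though those two can be told apart from each other.

The compounds shown leave open how a 3-fluorophenyl group would read, which would complete the set of single-fluorine rings, and how a phenyl ring carrying an amine or a carboxylic acid would read in its place. They also leave open whether any group on this nitrogen can produce marked growth inhibition at the concentration tested, and no measurement offered here explains the numbers seen so far.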